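Para-substituted phenyl ring in a dopamine D4 oxime series

A few compounds are considered here, and "the series" means these few. Any claim that something is new, unique, unknown or untested is made for them only; others in the source may bear on it.

The measured compounds are:
compound 1, `O/N=C(\CCN1CCN(c2ccccn2)CC1)c1cccc(F)c1`, 17.1 nM in a functional assay on HEK293 cells with D(4) dopamine receptor (Homo sapiens) as the target, read by FLIPR; on this read-out higher numbers stand for an effect only at larger amounts of compound and lower numbers for an effect already at smaller amounts;
compound 2, `N#Cc1cccc(/C(CCN2CCN(c3ccccn3)CC2)=N/O)c1`, 13.1 nM;
compound 3, `O/N=C(\CCN1CCN(c2ccccn2)CC1)c1ccc(Cl)cc1`, 475 nM.

Compound 3 gives the highest number of the three. Its nearest neighbour is compound 1, with a 28-fold higher number from compound 1 to compound 3 (1.44 log units; beyond the scatter), and the gap to compound 2 is wider still, with a 36-fold higher number from compound 2 to compound 3 (1.56 log units; beyond the scatter). The step from compound 1 to compound 2, a 1.3-fold lower number from compound 1 to compound 2 (0.12 log units; within the scatter), stays within the scatter.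

Compound 4, `O/N=C(\CCN1CCN(c2ccccn2)CC1)c1ccc(F)cc1F`, is the unmeasured compound. It differs from compound 3 in one place: 2,4-difluorophenyl in place of 4-chlorophenyl on a carbon with a double bond to nitrogen. Going by the values given here, no measured step introduces a 2,4-difluorophenyl, so the only bearing steps are the two large ones into compound 3, which show that a 4-chlorophenyl on the carbon double-bonded to nitrogen gives a far higher number than either 3-substituted phenyl. Compound 4 keeps a substituent at the 4-position and adds a second fluorine. For compound 4 the account therefore expects a number lower than that of compound 3 without reaching that of compound 1, an expected 3.2-fold lower number from compound 3 to compound 4 (0.50 log units; beyond the scatter). The estimate for compound 4 is 150 nM, ranging from 40 nM to 600 nM.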

Compound 4, half-maximal effective concentration: 8.9 nM
Beside the measured number, compound 4's estimate is 17-fold (1.23 log units) above it, outside the stated range (below it).
By their numbers in this assay, from the lowest: compounds 4, 2 and 1 (each within the scatter of the next); then compound 3.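

The step of a 53-fold lower number from compound 3 to compound 4 (1.73 log units; beyond the scatter) shows that, on the carbon with a double bond to nitrogen, the high number of compound 3 stays with the 4-chlorophenyl alone among the four groups seen at this place. The two remaining steps, a 1.5-fold lower number from compound 2 to compound 4 (0.17 log units; within the scatter) and a 1.9-fold lower number from compound 1 to compound 4 (0.28 log units; within the scatter), are both within the scatter, so in this assay the 2,4-difluorophenyl, the 3-cyanophenyl and the 3-fluorophenyl cannot be told apart. Nothing measured here gives a reason for this split between the 4-chlorophenyl and the other three groups.

Whether the high number of compound 3 follows from the chlorine or from the lack of a second fluorine stays open, as the compounds shown do not separate the two. Also open, as far as these compounds go, is how a phenyl carrying a methoxy or a trifluoromethyl group would read at this place.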